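The compounds below may be only part of what the source reports. "The series", "measured", "known", "first", "only" and "open" are said of these compounds alone.

Within the data shown here, in a functional assay on A549 cells (Homo sapiens) for inhibition, read by CCK-8 assay, with a stated time of 72 h, tested at 1 uM (a lower number here means less inhibition of growth, a higher number more inhibition of growth at the concentration tested), compound 2 `CN(C)C(=O)c1cc2cnc(Nc3ccc(NC(=O)C4(C(=O)Nc5ccc(Cl)c(C(F)(F)F)c5)CC4)cc3)nc2n1C1CCCC1` gives 1.1%, the lower of the two numbers so far, while compound 1 `CN(C)C(=O)c1cc2cnc(Nc3ccc(NC(=O)C4(C(=O)Nc5ccccc5F)CC4)cc3)nc2n1C1CCCC1` gives 79.1%. Compound 3 `COC(=O)c1cccc(NC(=O)C2(C(=O)Nc3ccc(Nc4ncc5cc(C(=O)N(C)C)n(C6CCCC6)c5n4)cc3)CC2)c1` is changed at one place, on an amide-type nitrogen: 3-(methoxycarbonyl)phenyl in place of 4-chloro-3-(trifluoromethyl)phenyl on an amide-type nitrogen. Among the measured compounds shown here, the only measured step bearing on this change is a number 78 percentage points lower from compound 1 to compound 2 (beyond the scatter), a large one at that same place. It shows that this place can matter greatly, but a single step cannot settle how the new group will behave, so a moderate rise is expected, a number 28.9 percentage points higher from compound 2 to compound 3 (beyond the scatter). For compound 3, the estimated value is 30%, within an expected range of 3% to 70%.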

Compound 3, percent growth inhibition at one concentration: 10.5%
Compound 3: middle estimate off by 19.5 percentage points, on the high side; the range from low to high includes it.
By their numbers in this assay, from the lowest: compounds 2 and 3 (each within the scatter of the next); then compound 1.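

In this assay, 3-(methoxycarbonyl)phenyl in place of 4-chloro-3-(trifluoromethyl)phenyl gives a number 9.4 percentage points higher from compound 2 to compound 3 (within the scatter) and so leaves these two different groups indistinguishable here. Measured against the 2-fluorophenyl of compound 1, the same new group gives a number 68.6 percentage points lower from compound 1 to compound 3 (beyond the scatter) and shows that a second, quite different group on this amide-type nitrogen also falls far short of compound 1. From the compounds shown here alone, how a plain phenyl, or a phenyl carrying an amine or a carboxylic acid, would score at this place remains open. No measurement given here accounts for these numbers.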